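Benzyl ring chlorination on the shared core

The source may report more compounds than this note shows. Statements on the series, on what has been measured and on what is new or still open speak of the compounds shown alone.

Compound 2 `O=c1ccc(-c2ccc3cn[nH]c3c2)cn1Cc1ccccc1` gives 75 nM in an assay for inhibition of MAP kinase-interacting serine/threonine-protein kinase 2 (Homo sapiens), read by luminescence and ADP-Glo, with a stated time of 2 h (on this read-out lower numbers stand for stronger inhibition and higher numbers for weaker inhibition), the highest of the two numbers in hand. Compound 1 `Nc1n[nH]c2cc(-c3ccc(=O)n(Cc4ccccc4)c3)ccc12`, differing only by the amino group, gives 32 nM, and the step is a 2.3-fold higher number from compound 1 to compound 2 (0.37 log units; beyond the scatter). Compound 3 `O=C(N1CCOCC1)n1cc(-c2ccc3cn[nH]c3c2)ccc1=O` reaches only the limit > 2000 nM in this assay. The step of an at least 26-fold higher number from compound 2 to compound 3 (1.42 log units; beyond the scatter) shows that the group on that aromatic nitrogen weighs heavily on the read-out. Compound 4 `O=c1ccc(-c2ccc3cn[nH]c3c2)cn1Cc1ccc(Cl)c(Cl)c1` carries the change (3,4-dichlorophenyl in place of phenyl on a saturated chain carbon bound to an aromatic nitrogen). Neither measured step alters the phenyl itself, so no direction can be drawn from them. Since the benzyl ring is kept, a step within the scatter is expected, a 1.3-fold lower number from compound 2 to compound 4 (0.10 log units; within the scatter). Compound 4 is estimated at 60 nM, with a range from 25 nM to 180 nM.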

Compound 4, half-maximal inhibitory concentration: 97 nM
Compound 4: the middle estimate sits 1.6-fold (0.21 log units) below what was measured; the range from low to high includes it.
By their numbers in this assay, from the lowest: compound 1; then compounds 2 and 4 (each within the scatter of the next). At a limit, above all of these: compound 3.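

On a saturated chain carbon bound to an aromatic nitrogen, 3,4-dichlorophenyl in place of phenyl gives a 1.3-fold higher number from compound 2 to compound 4 (0.11 log units; within the scatter). The earlier step at this nitrogen replaced the whole benzyl group, whereas this one shows that the phenyl ring can carry both chlorines with no shift beyond the scatter. No measurement shown bears on the reason for this result.

Open, as far as these compounds go, is how an amine or a carboxylic acid on the benzyl ring, or a longer chain on the aromatic nitrogen, would read. Also open, from the compounds shown here alone, is whether the amino group of compound 1 would give a similar step on compound 4.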